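Ester ethyl to isopropyl on two dihydropyrimidine cores

The source may report more compounds than this note shows. Statements on the series, on what has been measured and on what is new or still open speak of the compounds shown alone.

Three compounds have a number in an assay on cells for displacement of a labelled ligand from adenosine receptor A1 (Homo sapiens), with a stated time of 60 min, tested at 1 uM; on this read-out higher numbers stand for more inhibition at the one concentration tested (going by the name of the read-out) and lower numbers for less inhibition. Compound 1, `CCOC(=O)C1=C(C)NC(=O)NC1C1CCCC1`, gives 3%, the lowest of the three, with compound 2 and compound 3 both beyond the scatter above it. Compound 2, `CCOC(=O)C1=C(C)N/C(=N\C#N)NC1c1ccccc1`, gives 18%, and compound 3, `CC1=C(C(=O)OC(C)C)C(c2ccccc2)N/C(=N/C#N)N1`, gives 20%. The difference between the core of compound 1 and the core of compound 2 is not broken down here.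

Compound 3 differs from compound 2 by methyl in place of hydrogen on a saturated chain carbon bound to an oxygen next to a carbonyl group and a saturated chain carbon. That change made a step of a number 2 percentage points higher from compound 2 to compound 3 (within the scatter) in this assay.

Compound 4, `CC1=C(C(=O)OC(C)C)C(C2CCCC2)NC(=O)N1`, is not yet measured. It differs from compound 1 by methyl in place of hydrogen on a saturated chain carbon bound to an oxygen next to a carbonyl group and a saturated chain carbon, the same change, at the same place in the words given for both, though on the other core.

Among the measured compounds shown here, because the one measured instance of this change gave a number 2 percentage points higher from compound 2 to compound 3 (within the scatter), the step from compound 1 to compound 4 is expected to be about as small, a number 2 percentage points higher from compound 1 to compound 4 (within the scatter), and that rests on a single pair. Compound 4 is therefore estimated at 5%, between 0% and 15%, in this assay.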

Compound 4, a percentage reported as inhibition, at one concentration (the size of the read-out at that concentration, not a potency): 1%
The estimate for compound 4 lay 4 percentage points above the measured number; low and high end bracket the measured number.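

Working notes: in this assay, ethoxycarbonyl to isopropoxycarbonyl on the core of compound 1 gives a number 2 percentage points lower from compound 1 to compound 4 (within the scatter). Set beside the earlier step, the change behaves alike on the two cores, with no difference that stands out from the scatter: the same change on two cores in this assay, a number 2 percentage points higher (within the scatter) from compound 2 to compound 3 and a number 2 percentage points lower (within the scatter) from compound 1 to compound 4, 4 percentage points apart, within the scatter of two such steps. This supports only a modest statement, that ethyl to isopropyl at this place moves the number little on these two pairs, and it does not show that the change is without effect in general, since the read-out is inhibition at one concentration rather than a potency and none of the four compounds gives a high number.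

Open, from the compounds shown here alone, is whether a larger group at this ester, such as a longer chain or a benzyl group, or a carboxylic acid in its place, would move the number beyond the scatter. Also open, going by these compounds, is whether the two cores would part ways once the ester carries such a group.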